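A few compounds are considered here, and "the series" means these few. Any claim that something is new, unique, unknown or untested is made for them only; others in the source may bear on it.

Measured so far in a functional assay on MGC-803 cells (Homo sapiens) for antiproliferative activity, read by MTT assay, with a stated time of 72 h; on this read-out lower numbers stand for stronger inhibition and higher numbers for weaker inhibition:
- Compound 1 `C/C(=N\Nc1nc(SCc2ccccc2)nc2c1nnn2Cc1ccccc1)c1ccccc1O` gives 850 nM
- Compound 2 `CCCSc1nc(N/N=C/c2c[nH]c3ccccc23)c2nnn(Cc3ccccc3)c2n1` gives 7410 nM

Compound 2 has the higher of the two numbers, which makes it the weaker inhibitor, and its gap to compound 1 lies beyond the usual scatter. These two differ in more than one place, so the gap cannot be tied to any single change. Compound 3 `CCCSc1nc(N/N=C/c2ccccc2)c2nnn(Cc3ccccc3)c2n1` differs from compound 2 in one place only: it has phenyl in place of 1H-indol-3-yl on a carbon with a double bond to nitrogen and is otherwise the same. For the measured compounds named here, no measured pair shows this swap, so the expectation starts from compound 2 at 7410 nM and leans slightly towards a higher number, with no shift clearly beyond the scatter. The expected change is a 1.6-fold higher number from compound 2 to compound 3 (0.21 log units; within the scatter) on this estimate. For compound 3 the estimated value is 12000 nM with an expected range from 3500 nM to 40000 nM.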

Compound 3, half-maximal inhibitory concentration: > 64000 nM
Compound 3 ended at the assay's limit; the forecaster's own chance of this, stated with the estimate: 15%; at least 5.3-fold (0.72 log units) between middle value and limit.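

Here one change can be read on its own: on a carbon with a double bond to nitrogen, in this assay, phenyl in place of 1H-indol-3-yl gives an at least 8.6-fold higher number from compound 2 to compound 3 (0.93 log units; beyond the scatter). At this position, then, the change is not neutral, and phenyl does not keep the activity of compound 2; the change removes the five-membered aromatic ring and its hydrogen-bond donor. Compound 3 stands at a limit of the assay rather than at a number, so the step gives only a minimum size: the limit of > 64000 nM in this assay, at which 1 of the 3 values shown sits.

The compounds shown do not tell whether the lost ring or the lost donor matters more. From the compounds shown here alone, it also remains open whether a pyridyl group or an aminophenyl group in this place would restore activity.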